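A few compounds are considered here, and "the series" means these few. Any claim that something is new, unique, unknown or untested is made for them only; others in the source may bear on it.

Inhibition in a functional assay on the whole organism (CCRF S-180 cells, Mus musculus) for inhibition, in a xenograft, with stated times of 7 days and 24 h, at a dose of 100 umol/kg by the intraperitoneal route; on this read-out higher numbers stand for more inhibition at the one dose given (going by the name of the read-out) and lower numbers for less inhibition:

compound 1, `O=C(CC[C@H](NC(=O)c1cc2ccccc2cn1)C(=O)OCc1ccccc1)OCc1ccccc1`: 25.2%
compound 2, `CC(C)[C@H](NC(=O)c1cc2ccccc2cn1)C(=O)OCc1ccccc1`: 29.7%
compound 3, `C[C@H](NC(=O)c1cc2ccccc2cn1)C(=O)OCc1ccccc1`: 40.6%

Compound 3 stands highest of the three numbers; the two steps up to it are a number 10.9 percentage points higher from compound 2 to compound 3 (beyond the scatter) and a number 15.4 percentage points higher from compound 1 to compound 3 (beyond the scatter), both beyond the scatter. Between compound 1 and compound 2 the step is a number 4.5 percentage points higher from compound 1 to compound 2 (within the scatter), within the scatter.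

Compound 4, `NCCCC[C@H](NC(=O)c1cc2ccccc2cn1)C(=O)OCc1ccccc1`, differs from compound 3 by 3-aminopropyl in place of hydrogen on a saturated chain carbon, two bonds along the chain from an amide-type nitrogen and a carbonyl carbon.

The two steps that bear on this are a number 15.4 percentage points higher from compound 1 to compound 3 (beyond the scatter) and a number 10.9 percentage points higher from compound 2 to compound 3 (beyond the scatter): in both, the compound with more carbon at the chain position bound to the amide-type nitrogen gives the lower number, and the hydrogen of compound 3 gives the highest. Among the measured compounds shown here, the entering 3-aminopropyl is a chain of the same kind, though no measured compound carries an amine, so the read-across is indirect. A downward step, a number 11.6 percentage points lower from compound 3 to compound 4 (beyond the scatter), is therefore expected for compound 4, of modest size. Compound 4 is estimated at 29%, with a range of 15% to 44%.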

Compound 4, a percentage reported as inhibition, in the whole organism at one dose (the size of the read-out at that dose, not a potency): 40.6%
Compound 4: the middle estimate sits 11.6 percentage points below what was measured; the measured number falls inside the stated range.
By their numbers in this assay, from the lowest: compounds 1 and 2 (each within the scatter of the next); then compounds 3 and 4 (each within the scatter of the next).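

In this assay, no change at the digits printed from compound 3 to compound 4 (within the scatter), so the 3-aminopropyl chain on this saturated chain carbon places compound 4 level with compound 3, whereas the larger groups in compounds 1 and 2 both gave lower numbers than compound 3. The 4-aminobutyl chain also stands clear of the other side chains, with a number 10.9 percentage points higher from compound 2 to compound 4 (beyond the scatter) and a number 15.4 percentage points higher from compound 1 to compound 4 (beyond the scatter), so a long chain at this position does not by itself go with a lower number in this series. Nothing in hand accounts for this result.

Going by these compounds, whether the terminal amine is what separates compound 4 from compounds 1 and 2 stays open, and a plain butyl chain or a 4-hydroxybutyl chain would bear on that. Also open, on these data alone, is how a shorter aminoethyl chain or a free carboxylic acid at this position would read in this assay.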